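Hydroxy Replaced by Nitro across Two Related Cores

A few compounds are considered here, and "the series" means these few. Any claim that something is new, unique, unknown or untested is made for them only; others in the source may bear on it.

Of the compounds shown here, three have been measured in an ADME assay on cells (Peritoneal macrophage, Mus musculus, strain BALB/c) for cytotoxicity, with a stated time of 72 h; on this read-out higher numbers stand for lower toxicity in this test and lower numbers for higher toxicity in this test. Compound 1, `Oc1ccc(O)c(/C=N/Nc2ncccn2)c1`, gives 89400 nM in this assay. Compound 2, `O=[N+]([O-])c1ccc(O)c(/C=N/Nc2ncccn2)c1`, gives 23800 nM in this assay. Compound 3, `O=C(N/N=C/c1cc(O)ccc1O)c1ncccn1`, is reported in this assay only as a limit, > 150000 nM, and the value is a limit of the assay rather than a number (the limit of > 150000 nM in this assay, at which 1 of the 3 values shown sits).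

The step from compound 1 to compound 2 is nitro in place of hydroxy on an aromatic carbon, and in this assay it produced a 3.8-fold lower number from compound 1 to compound 2 (0.57 log units; beyond the scatter). How the core of compound 3 differs from the core of compound 1 is not broken down here.

Compound 4, `O=C(N/N=C/c1cc([N+](=O)[O-])ccc1O)c1ncccn1`, has not yet been measured. It relates to compound 3 by nitro in place of hydroxy on an aromatic carbon. This is the same kind of change as that from compound 1 to compound 2, though the surroundings are described a little differently: in compound 1 the group is meta to a group of 9 heavy atoms, whereas in compound 3 it is meta to a large group, and in both cases para to a hydroxy group.

Compound 4 is expected to show in this assay a number near 60000 nM, with a range from 20000 nM to 150000 nM. From the compounds shown here alone, the expected step for compound 4 is an at least 2.5-fold lower number from compound 3 to compound 4 (0.39 log units; beyond the scatter), resting on a 3.8-fold lower number from compound 1 to compound 2 (0.57 log units; beyond the scatter) and on the fact that compound 3 stands at a limit, so its true starting point is unknown.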

Compound 4, half-maximal cytotoxic concentration: 63400 nM
The estimate for compound 4 lay 1.1-fold (0.02 log units) below the measured number, within the range that was stated.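

In this assay, nitro in place of hydroxy on an aromatic carbon again went with a lower number on the second core, giving an at least 2.3-fold lower number from compound 3 to compound 4 (0.37 log units; beyond the scatter), so the direction seen on the core of compound 1 also appears on the core of compound 3. Set side by side, the two results show agreement in direction and beyond the scatter, but no equal size: the same change on two cores in this assay, a 3.8-fold lower number (0.57 log units; beyond the scatter) from compound 1 to compound 2 and an at least 2.3-fold lower number (0.37 log units; beyond the scatter) from compound 3 to compound 4; the limit leaves it open whether they differ. Compound 3 gives > 150000 nM, which is a limit of the assay and not a number, so the pair shows that the direction carried over between these two cores and does not show how large the step on the second core truly is: the limit of > 150000 nM in this assay, at which 1 of the 4 values shown sits.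

The compounds shown leave open how other groups on that aromatic carbon, such as an amine, a methoxy group or a carboxylic acid, would stand in this assay on either core. They also leave open whether the same change would go the same way on any core beyond these two, since two cores are too few to make it a rule for the series.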